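The compounds below may be only part of what the source reports. "The series", "measured", "known", "first", "only" and "open" are said of these compounds alone.

Series so far, measured in a functional assay on HL-60 cells (Homo sapiens) for inhibition, read by MTT assay, with a stated time of 72 h; a higher number here means a weaker inhibitor, a lower number a stronger inhibitor:
- compound 1 `COc1ccc(-c2nc(C)oc2C(=O)N2CCN(c3cccc(Cl)c3)CC2)cc1`: "not active" (no number reported)
- compound 2 `CCc1nc(-c2ccc(F)cc2)c(C(=O)N2CCN(c3cccc(Cl)c3)CC2)o1`: 169 nM

Among the measured compounds shown here, compound 2 holds the only number in the set, since compound 1 gave none, so no step between measured compounds is available to calibrate a change. Next is compound 3 `CCc1nc(-c2ccc(OC)cc2)c(C(=O)N2CCN(c3cccc(Cl)c3)CC2)o1`, which departs from compound 2 at one place: methoxy in place of fluoro on an aromatic carbon, para to a large group.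

In this assay a moderate loss of potency is expected, with a wide margin. The estimated change is a 2.4-fold higher number from compound 2 to compound 3 (0.37 log units; beyond the scatter) and it points towards a weaker inhibitor. This lean rests only on compound 1 at "not active" (no number reported) and remains tentative. Compound 3 is expected at 400 nM with an estimated range of 80 nM to 2500 nM as the likely span.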

Compound 3, half-maximal inhibitory concentration: > 1000 nM
Compound 3 was reported as a limit; the forecaster's own chance of this, stated with the estimate: 20%; middle value at least 2.5-fold (0.39 log units) from the limit.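

In this assay, the change from 4-fluorophenyl to 4-methoxyphenyl gives the series its first readable step: an at least 5.9-fold higher number from compound 2 to compound 3 (0.77 log units; beyond the scatter). Compound 3 is reported as a limit, > 1000 nM, not as a number. On this one pair, methoxy in place of fluoro, para to a large group, costs potency, and the size of that loss can be read only as far as the limit allows: the limit of > 1000 nM in this assay, at which 1 of the 3 values shown sits.

As far as these compounds go, whether other groups at this position, such as chloro, hydroxy or a longer alkoxy chain, would keep the potency of compound 2 remains open, as does whether an unsubstituted phenyl would. Compound 1 also carries 4-methoxyphenyl and gives "not active" (no number reported), so no step can be read between it and compound 3.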